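The compounds below may be only part of what the source reports. "The series", "measured", "known", "first", "only" and "open" are said of these compounds alone.

Compound 1 `O=C(Sc1cccnc1C(=O)O)c1cccc(C(F)(F)F)c1` and compound 2 `O=C(Sc1cccnc1C(=O)O)c1ccc(C(F)(F)F)cc1` are built from the same atoms joined differently; the difference between the two cores is not broken down here. In a physicochemical assay for pharmacokinetics, at pH 8 (a higher number here means that the compound lasts longer, a lower number that the compound disappears faster), compound 1 gives 10 h, and compound 2 gives 10.1 h, the two numbers lying within the scatter of each other. Compound 3 `COc1cccc(C(=O)Sc2cccnc2C(=O)O)c1` arises from compound 1 by one change, (methoxy in place of trifluoromethyl on an aromatic carbon), and in this assay compound 3 gives 63.7 h, a step of a 6.4-fold higher number from compound 1 to compound 3 (0.80 log units; beyond the scatter). Compound 4 `COc1ccc(C(=O)Sc2cccnc2C(=O)O)cc1` has not yet been measured. It stands to compound 2 as compound 3 stands to compound 1, by the same kind of change, (methoxy in place of trifluoromethyl on an aromatic carbon), although in compound 4 the entering group sits para to a large group, whereas in compound 3 it sits meta to a large group. Within the data shown here, the step from compound 2 to compound 4 in this assay is expected to be a 5.9-fold higher number from compound 2 to compound 4 (0.77 log units; beyond the scatter), an expectation that rests on the one measured example of this change, which gave a 6.4-fold higher number from compound 1 to compound 3 (0.80 log units; beyond the scatter). A single example at a different place around the ring is thin footing, so the range is kept wide. Compound 4 is accordingly expected to give about 60 h, somewhere between 25 h and 150 h.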

Compound 4, half-life: 182 h
Beside the measured number, compound 4's estimate is 3.0-fold (0.48 log units) below it; measured number outside the range, above it.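

In this assay, replacing trifluoromethyl with methoxy gives an 18-fold higher number from compound 2 to compound 4 (1.26 log units; beyond the scatter) and so repeats on a second core the direction of a 6.4-fold higher number from compound 1 to compound 3 (0.80 log units; beyond the scatter) with both steps lying beyond the scatter. The direction therefore carries across these two cores, but the size is not shown to carry, since the new step ranks as large and the earlier one as modest, and two pairs cannot separate the effect of the core from that of where the entering group sits on the ring or show that the direction would hold on any further core. Nothing given here bears on why the step arises or why its size differs between the two pairs.

From the compounds shown here alone, only trifluoromethyl and methoxy are compared in this change, so it remains open how an amine, a nitrile or a longer chain such as ethoxy would behave in the same place. Going by these compounds, it also remains open whether the step seen with methoxy on these two cores would appear with any of those groups.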